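Replacing 3-methoxyphenyl in the compound 3 series

The source may report more compounds than this note shows. Statements on the series, on what has been measured and on what is new or still open speak of the compounds shown alone.

Values in a functional assay on A549 cells (Homo sapiens) for cytotoxicity, read by MTT assay; a higher number here means a weaker inhibitor, a lower number a stronger inhibitor:
- compound 1 `COc1cccc(-c2cc(-c3c(O)c4ccccc4oc3=O)nc(N)c2C#N)c1`: 2380 nM
- compound 2 `N#Cc1c(-c2c(F)cccc2Cl)cc(-c2c(O)c3ccccc3oc2=O)nc1N`: 46300 nM
- compound 3 `COc1cccc(-c2cc(-c3c(O)c4ccccc4oc3=O)nc(O)n2)c1`: 5550 nM

Compound 3 holds the middle of the three numbers, above compound 1 and below compound 2. Compound 4 `O=c1oc2ccccc2c(O)c1-c1cc(-c2c(F)cccc2Cl)nc(O)n1` differs from it at one place, on an aromatic carbon of a six-membered aromatic ring with 2 nitrogen: 2-chloro-6-fluorophenyl in place of 3-methoxyphenyl on an aromatic carbon. Going by the values given here, only one measured step bears on this, the same replacement on the core of compound 1: a 19-fold higher number from compound 1 to compound 2 (1.29 log units; beyond the scatter). That step is large, but it is a single case on a different core, so a higher number in this assay is expected, though with only part of that size carried over. The expected step is a 6.3-fold higher number from compound 3 to compound 4 (0.80 log units; beyond the scatter). For compound 4 the estimate is 35000 nM, with an expected range of 10000 nM to 110000 nM.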

Compound 4, half-maximal inhibitory concentration: 5100 nM
Compound 4: the middle estimate sits 6.9-fold (0.84 log units) above what was measured; measured number below the stated range.
By their numbers in this assay, from the lowest: compound 1; then compounds 4 and 3 (each within the scatter of the next); then compound 2.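

In this assay, 2-chloro-6-fluorophenyl in place of 3-methoxyphenyl gives a 1.1-fold lower number from compound 3 to compound 4 (0.04 log units; within the scatter), so on this core the exchange leaves the reading within the scatter. The large rise seen on the core of compound 1 does not carry over, and the outcome of this change at this position depends on the core that carries it: the same change on two cores in this assay, a 19-fold higher number (1.29 log units; beyond the scatter) from compound 1 to compound 2 and a 1.1-fold lower number (0.04 log units; within the scatter) from compound 3 to compound 4, 21-fold (1.33 log units) apart, beyond the scatter of two such steps.

Still open is which part of the two cores accounts for this gap. Also open, on these data alone, is how an amine or a carboxylic acid at this position would read on either core.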